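Compound 4: restoring an aryl group where compound 3 fails

The source may report more compounds than this note shows. Statements on the series, on what has been measured and on what is new or still open speak of the compounds shown alone.

The series shares one core, varied at a single aromatic carbon. Compound 1 `Cc1cc(NC(=O)Cn2nnc(-c3ccccc3)n2)n(C2CCCCC2)n1` carries phenyl there, and in an assay on HEK293 cells for activation of Kir3.1/Kir3.2 (Homo sapiens), read by thallium flux (on this read-out higher numbers stand for an effect only at larger amounts of compound and lower numbers for an effect already at smaller amounts), compound 1 gives 96 nM. Compound 2 `Cc1cc(NC(=O)Cn2nnc(-c3ccc(F)c(F)c3)n2)n(C2CCCCC2)n1` carries 3,4-difluorophenyl, and in this assay compound 2 gives 116 nM; the change between them is a 1.2-fold higher number from compound 1 to compound 2 (0.08 log units; within the scatter). Compound 3 `Cc1cc(NC(=O)Cn2nnc(C3CC3)n2)n(C2CCCCC2)n1` carries cyclopropyl instead. For compound 3 this assay reports only a limit, > 3000 nM, so compound 3 sits at the limit of > 3000 nM in this assay, at which 1 of the 3 values shown sits, and no number is known for it. Going by the values given here, compound 3 therefore stands at the weak end of the numbers so far; the loss from the aryl compounds is an at least 31-fold higher number from compound 1 to compound 3 (1.49 log units; beyond the scatter) and an at least 25-fold higher number from compound 2 to compound 3 (1.41 log units; beyond the scatter).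

Compound 4 `Cc1cc(NC(=O)Cn2nnc(-c3cccc(C(F)(F)F)c3)n2)n(C2CCCCC2)n1` differs from compound 3 by 3-(trifluoromethyl)phenyl in place of cyclopropyl on an aromatic carbon. This reverses the direction of the change behind an at least 31-fold higher number from compound 1 to compound 3 (1.49 log units; beyond the scatter) and an at least 25-fold higher number from compound 2 to compound 3 (1.41 log units; beyond the scatter), and it brings in a substituted aryl group of the kind seen in compound 2, where a 1.2-fold higher number from compound 1 to compound 2 (0.08 log units; within the scatter) stayed within the scatter. A large step downward in this assay is therefore expected, back toward the numbers of compound 1 and compound 2. For compound 4 the expected step is an at least 20-fold lower number from compound 3 to compound 4 (1.30 log units; beyond the scatter). The estimate for compound 4 in this assay is 150 nM, with a range from 50 nM to 600 nM. Among the compounds with values here, no measured pair tests a trifluoromethyl substituent on the aryl group, so the range is kept wide.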

Compound 4, half-maximal effective concentration: 183 nM
For compound 4 the middle estimate is 1.2-fold (0.09 log units) below the measured one; measured number inside the range.
By their numbers in this assay, from the lowest: compounds 1, 2 and 4 (each within the scatter of the next). At a limit, above all of these: compound 3.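

In this assay an aryl group at this aromatic carbon, between two ring nitrogen atoms, again gives a measurable number, with an at least 16-fold lower number from compound 3 to compound 4 (1.21 log units; beyond the scatter) for 3-(trifluoromethyl)phenyl in place of cyclopropyl, so the loss seen in compound 3 does not extend to a third aryl group. The position also accepts a larger substituent on the phenyl ring: a 1.9-fold higher number from compound 1 to compound 4 (0.28 log units; within the scatter) on adding trifluoromethyl and a 1.6-fold higher number from compound 2 to compound 4 (0.20 log units; within the scatter) against 3,4-difluorophenyl both leave compounds 1, 2 and 4 within the scatter of one another, with compound 3 the only one shown that falls outside this group. Going by these compounds, compound 3 is reported only as a limit, so the full size of the step from it stays unknown: the limit of > 3000 nM in this assay, at which 1 of the 4 values shown sits.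

With cyclopropyl the only non-aryl group shown, it remains open whether the loss follows from the missing aromatic ring or from the lower count of heavy atoms, and a cyclohexyl group at this carbon would help separate the two. The phenyl substituents shown are limited to fluorine and trifluoromethyl, which leaves open how an amine, a carboxylic acid or a methoxy group on that ring would read.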